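From 4-methylbenzyl to 2-chlorobenzyl: a small expected step

The source may hold more compounds than are shown below. What is called first, only, known or untested is meant among the compounds shown, and "the series" means these compounds.

- Compound 1 `CC1CCN(Cc2ccc3nc(NC(=O)N/N=C/c4cn(Cc5ccc(Cl)cc5Cl)c5ccccc45)sc3c2)CC1`: 3640 nM
- Compound 2 `CC1CCN(Cc2ccc3nc(NC(=O)N/N=C/c4cn(Cc5cccc(Cl)c5)c5ccccc45)sc3c2)CC1`: 2810 nM
- Compound 3 `Cc1ccc(Cn2cc(/C=N/NC(=O)Nc3nc4ccc(CN5CCC(C)CC5)cc4s3)c3ccccc32)cc1`: 2180 nM
- Compound 4 `CC1CCN(Cc2ccc3nc(NC(=O)N/N=C/c4cn(Cc5ccccc5Cl)c5ccccc45)sc3c2)CC1`: not yet measured

In a functional assay on A549 cells (Homo sapiens) for cytotoxicity, read by MTT assay, with a stated time of 72 h (a lower number here means a stronger inhibitor, a higher number a weaker inhibitor), compound 3 gives 2180 nM, which cannot be told apart from the other two compounds. The next change replaces 4-methylphenyl with 2-chlorophenyl on a saturated chain carbon bound to an aromatic nitrogen: 2-chlorophenyl in place of 4-methylphenyl on a saturated chain carbon bound to an aromatic nitrogen.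

Three measured steps change this same group. They are a 1.3-fold lower number from compound 1 to compound 2 (0.11 log units; within the scatter), a 1.7-fold lower number from compound 1 to compound 3 (0.22 log units; within the scatter) and a 1.3-fold lower number from compound 2 to compound 3 (0.11 log units; within the scatter). All three stay within the scatter, so among these compounds the swaps have not clearly moved the number. Going by the values given here, no measured compound carries 2-chlorophenyl itself, although compound 1 and compound 2 both have chlorine on this ring. With so little to go on, no step beyond the scatter is expected in this assay, and no direction can be firmly expected.

The estimate amounts to an expected 1.3-fold higher number from compound 3 to compound 4 (0.11 log units; within the scatter). For compound 4 the estimated value is 2800 nM, with an expected range from 1400 nM to 5600 nM.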

Compound 4, half-maximal inhibitory concentration: 3330 nM
Compound 4: the middle estimate sits 1.2-fold (0.08 log units) below what was measured; the measured number falls inside the stated range.
By their numbers in this assay, from the lowest: compounds 3, 2, 4 and 1 (each within the scatter of the next).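

In this assay, 2-chlorophenyl now joins the groups on this saturated chain carbon bound to an aromatic nitrogen, and all of its steps stay within the scatter (a 1.5-fold higher number from compound 3 to compound 4 (0.18 log units; within the scatter)), (a 1.2-fold higher number from compound 2 to compound 4 (0.07 log units; within the scatter)) and (a 1.1-fold lower number from compound 1 to compound 4 (0.04 log units; within the scatter)). Moving the chlorine from 3-chlorophenyl to 2-chlorophenyl has therefore not clearly moved the number, and neither has hydrogen in place of chloro when 2,4-dichlorophenyl becomes 2-chlorophenyl. Nothing measured here explains why these changes leave the number so flat.

All four rings shown carry only chloro or methyl, so it remains open whether any change at this place can produce a step beyond the scatter. A methoxy group, an amine or a carboxylic acid on this ring could test that, as could a longer chain in place of the benzyl link.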